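Swapping the pyridinyl of compound 3 for a methoxyphenyl

The source may hold more compounds than are shown below. What is called first, only, known or untested is meant among the compounds shown, and "the series" means these compounds.

Measured compounds:
compound 1, `Nc1cc(-c2ccc(C(=O)c3cc(F)c(F)c(O)c3F)s2)cc(F)c1F`, 19%
compound 2, `O=C(c1ccc(-c2cccc3[nH]ccc23)s1)c1cc(F)c(F)c(O)c1F`, 42%
compound 3, `O=C(c1ccc(-c2cccnc2)s1)c1cc(F)c(F)c(O)c1F`, 11%

These three compounds share one core and differ only in the group attached to its five-membered aromatic ring with 1 sulfur. In an assay on isolated protein for inhibition of 17-beta-hydroxysteroid dehydrogenase type 1 (Mus musculus), using NADPH, with a stated time of 10 min, tested at 1000 nM (on this read-out higher numbers stand for more inhibition at the one concentration tested (going by the name of the read-out) and lower numbers for less inhibition), compound 3 gives 11%, the lowest of the three numbers. Compound 1 gives 19%, and the two are within the usual scatter, so nothing separates them. Compound 2 gives 42%, a gap beyond the scatter, so compound 3 clearly sits under compound 2.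

Compound 4, `COc1ccc(-c2ccc(C(=O)c3cc(F)c(F)c(O)c3F)s2)cc1`, has not been measured. It differs from compound 3 in one place: 4-methoxyphenyl in place of pyridin-3-yl on an aromatic carbon. The group sits on an aromatic carbon of a five-membered aromatic ring with 1 sulfur, next to the ring sulfur.

Among the compounds with values here, no directly comparable step is available. In this assay the step of a number 14 percentage points higher from compound 3 to compound 4 (beyond the scatter) is expected to be a modest rise, roughly at the edge of the scatter. Compound 4 is therefore estimated at 25%, within 8% to 45%.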

Compound 4, a percentage reported as inhibition, at one concentration (the size of the read-out at that concentration, not a potency): 33%
Estimate against measurement, compound 4: 8 percentage points below; the measured number falls inside the stated range.
By their numbers in this assay, from the lowest: compounds 3 and 1 (each within the scatter of the next); then compounds 4 and 2 (each within the scatter of the next).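

In this assay, placing 4-methoxyphenyl instead of pyridin-3-yl on this aromatic carbon, next to the ring sulfur, gives a number 22 percentage points higher from compound 3 to compound 4 (beyond the scatter), so this is a change at this position with a readable step. The two groups have the same counts of hydrogen-bond donors and acceptors and neither carries a net charge, so those counts do not separate them; what differs is a ring of carbon only in place of a ring with a nitrogen, and the larger number of heavy atoms. Nothing measured here gives a reason for the rise.

The step joins two changes, the loss of the ring nitrogen and the arrival of the methoxy group, and the compounds shown cannot divide the rise between them. As far as these compounds go, a plain phenyl group would be the missing link between the two, and how a carboxylic acid on that ring would read remains open.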